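Swapping the alkyne chain for a cyclopropyl on the ether

The compounds below may be only part of what the source reports. "The series", "measured", "known", "first", "only" and "open" are said of these compounds alone.

Compound 1, `CCCOc1cccc2ccc(N)nc12`: 1100 nM in an assay on cells with melanin-concentrating hormone receptor 1 (Homo sapiens) as the target, read by radioligand binding; a higher number here means a weaker inhibitor, a lower number a stronger inhibitor.
Compound 2, `CCC#CCOc1cccc2ccc(N)nc12`: > 2000 nM in this assay, a limit of the assay rather than a number.

Both compounds share one core and differ only in the chain that sits on the oxygen of the aromatic ring. In this assay compound 1 gives 1100 nM. For compound 2 the assay reports only a limit, > 2000 nM, so its true value is not known; it stands at the limit of > 2000 nM in this assay, at which 1 of the 2 values shown sits. Among the compounds with values here, the one measured step, an at least 1.8-fold higher number from compound 1 to compound 2 (0.25 log units; that floor lies within the scatter), is therefore itself only a floor.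

Compound 3, `Nc1ccc2cccc(OCC3CC3)c2n1`, differs from compound 2 by cyclopropyl in place of but-1-yn-1-yl on a saturated chain carbon bound to an oxygen on an aromatic ring. Within the data shown here, the single measured step bears on this only loosely: it says that lengthening the chain with a triple bond did not help, but it does not say how far compound 2 actually lies past the limit. Returning to a smaller saturated group is expected to bring the number back toward that of compound 1, so the step of an at least 1.3-fold lower number from compound 2 to compound 3 (0.12 log units; that floor lies within the scatter) is expected to run downward, though its size is uncertain. The estimate for compound 3 in this assay is 1500 nM, with a range from 500 nM to 5000 nM.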

Compound 3, half-maximal inhibitory concentration: > 2000 nM
Compound 3: only a limit was reported; the forecaster's own chance of this, stated with the estimate: 35%; at least 1.3-fold (0.12 log units) between middle value and limit.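

In this assay compound 3 gives > 2000 nM, a limit of the assay and not a number. On this saturated chain carbon bound to an oxygen on an aromatic ring, cyclopropyl now joins but-1-yn-1-yl: one group carries a three-membered ring and the other a triple bond, yet neither gives a value that can be read. The one readable step, an at least 1.8-fold higher number from compound 1 to compound 3 (0.25 log units; that floor lies within the scatter), is only a floor, and the step between the two limits cannot be read, so these two groups cannot be put in order and the series stands as follows: the limit of > 2000 nM in this assay, at which 2 of the 3 values shown sit.

On these data alone, how far compound 2 and compound 3 each lie past the limit stays open, so any real loss against the smaller chain remains unsized. Also open, as far as these compounds go, is whether another group on this carbon, such as an amine, a hydroxyl or a phenyl, would give a readable value, and whether any such group would clearly improve on compound 1, at 1100 nM.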